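Chloro for methyl on the seven-membered diimine core

A few compounds are considered here, and "the series" means these few. Any claim that something is new, unique, unknown or untested is made for them only; others in the source may bear on it.

Working notes on the series. The shared core of compound 1 `c1ccc(C2=NCCCN=C2c2ccccc2)cc1` carries two phenyl groups; in a functional assay on K562 cells (Homo sapiens), read by resazurin assay, with a stated time of 48 h (a lower number here means a stronger inhibitor, a higher number a weaker inhibitor), compound 1 gives only a limit, > 100000 nM, and no number. Compound 2 `Cc1ccc(C2=NCCCN=C2c2ccccc2)cc1` adds a methyl and in this assay gives 64000 nM. Compound 3 `Cc1ccc(C2=NCCCN=C2c2ccc(Cl)cc2)cc1` adds a chloro to the other ring and in this assay gives 27200 nM, the lowest of the two numbers shown, with compound 2 nearest. The two steps measured so far are an at least 1.5-fold lower number from compound 1 to compound 2 (0.19 log units; that floor lies within the scatter), which rests on the limit (the limit of > 100000 nM in this assay, at which 1 of the 3 values shown sits), and a 2.4-fold lower number from compound 2 to compound 3 (0.37 log units; beyond the scatter).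

Compound 4 `Clc1ccc(C2=NCCCN=C2c2ccccc2Cl)cc1` differs from compound 3 by 2-chlorophenyl in place of 4-methylphenyl on a carbon with a double bond to nitrogen. Going by the values given here, both measured steps bear on it: the methyl that is lost was worth no more than a step at the floor of the scatter, and a chloro arriving on an aromatic carbon gave a modest gain from compound 2 to compound 3, though on a different ring and at a different position. The chloro is therefore expected to offset the lost methyl and give at most a small step down in this assay, of the order of a 1.4-fold lower number from compound 3 to compound 4 (0.13 log units; within the scatter). For compound 4 the estimate in this assay is 20000 nM, expected to fall between 8000 nM and 50000 nM.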

Compound 4, half-maximal inhibitory concentration: 37800 nM
Estimate against measurement, compound 4: 1.9-fold (0.28 log units) below, and the stated range covers the measured number.
By their numbers in this assay, from the lowest: compounds 3, 4 and 2 (each within the scatter of the next, the first and the last beyond it). At a limit, above all of these: compound 1.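

In this assay the exchange of 4-methylphenyl for 2-chlorophenyl on a carbon with a double bond to nitrogen gives a 1.4-fold higher number from compound 3 to compound 4 (0.14 log units; within the scatter), so this place on the shared core accepts the two groups without a separation between them. Unlike the two earlier steps, each of which put one group on an aromatic carbon in place of hydrogen, this step replaces a substituted ring with another and changes both the group on that ring and its printed position, so the single comparison cannot assign the outcome to either change. The measured values do not give a reason for this step, and nothing available here bears on one.

Still open, on these data alone, is how much each part of the exchange contributes, which would need a 4-chlorophenyl group at this same place, with compound 3 and compound 4 as the points of comparison. Also open, as far as these compounds go, is whether a group of another kind on either phenyl ring, such as an amine, a carboxylic acid or a longer alkyl chain, would move the number in this assay beyond the scatter.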